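Swapping the ether for a phenyl on the shared core

A few compounds are considered here, and "the series" means these few. Any claim that something is new, unique, unknown or untested is made for them only; others in the source may bear on it.

Measured so far:
compound 1, `COc1ccccc1N1CCN(CCCNc2ncccc2C(=O)N(C)C)CC1`: 20 nM
compound 2, `CN(C)C(=O)c1cccnc1NCCCN1CCN(c2ccccc2O)CC1`: 63.1 nM
compound 3, `CN(C)C(=O)c1cccnc1NCCCN1CCN(c2ccccc2OCC(F)(F)F)CC1`: 15.9 nM

All three compounds were tested in a functional assay on aorta for antagonist activity at Alpha-1D adrenergic receptor (Rattus norvegicus); a higher number here means weaker binding, a lower number tighter binding. Compound 3 gives the lowest number of the three; its nearest neighbour is compound 1, and the gap between them, a 1.3-fold lower number from compound 1 to compound 3 (0.10 log units; within the scatter), is within the scatter, so the two cannot be ordered. Its furthest neighbour is compound 2, separated by a 4.0-fold lower number from compound 2 to compound 3 (0.60 log units; beyond the scatter).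

Compound 4, `CN(C)C(=O)c1cccnc1NCCCN1CCN(c2ccccc2-c2ccccc2)CC1`, has not been measured. It differs from compound 3 in one place: phenyl in place of 2,2,2-trifluoroethoxy on an aromatic carbon.

The three measured steps all change the group on this same aromatic carbon. Removing the methyl gave a 3.2-fold higher number from compound 1 to compound 2 (0.50 log units; beyond the scatter), and adding the trifluoroethyl gave a 4.0-fold lower number from compound 2 to compound 3 (0.60 log units; beyond the scatter). None of them replaces the oxygen-linked group with a ring, so there is no direct guide. Given that all changes here stayed within a modest span, compound 4 is expected to land near compound 3, with the step of a 1.9-fold higher number from compound 3 to compound 4 (0.28 log units; within the scatter) estimated but uncertain in direction. Compound 4 is therefore estimated at 30 nM, within 8 nM to 120 nM.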

Compound 4, dissociation constant: 63.1 nM
Compound 4: middle estimate off by 2.1-fold (0.32 log units), on the low side, within the range that was stated.
By their numbers in this assay, from the lowest: compounds 3 and 1 (each within the scatter of the next); then compounds 2 and 4 (each within the scatter of the next).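

Going by these compounds alone, compound 4 is the only compound here whose group on this aromatic carbon holds no oxygen, and in this assay replacing 2,2,2-trifluoroethoxy with phenyl gives a 4.0-fold higher number from compound 3 to compound 4 (0.60 log units; beyond the scatter) even though both groups have 6 heavy atoms, so that count alone does not set the number. Replacing methoxy with phenyl gives a 3.2-fold higher number from compound 1 to compound 4 (0.50 log units; beyond the scatter) in the same direction, while replacing hydroxy with phenyl gives no change at the digits printed from compound 2 to compound 4 (within the scatter) and leaves those two compounds level. No measurement is available that explains these steps.

A phenoxy group, which would place an oxygen and a phenyl ring together on this carbon, could help separate the effect of losing the oxygen from that of adding the ring. From the compounds shown here alone, how an amine on this carbon would compare also remains open.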